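The source may report more compounds than this note shows. Statements on the series, on what has been measured and on what is new or still open speak of the compounds shown alone.

Measured so far:
compound 2 `CS(=O)(=O)Nc1ccc(NC(=O)c2ccc(C#N)cc2)cc1F`, which in an ADME assay on HEK293 cells (Homo sapiens) for cytotoxicity, read by MTT assay, with a stated time of 48 h (on this read-out higher numbers stand for weaker inhibition and lower numbers for stronger inhibition), gives > 250000 nM;
compound 1 `CCS(=O)(=O)Nc1ccc(NC(=O)c2ccc(C#N)cc2)cc1OC`, which in this assay gives > 250000 nM.

Both of these values are limits of the assay rather than numbers. For compound 2 the value > 250000 nM is such a limit. For compound 1 the value > 250000 nM is likewise a limit. Compound 2 therefore stands at the limit of > 250000 nM in this assay, at which 2 of the 2 values shown sit, and nothing in these numbers sets it apart from compound 1.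

Compound 3 `CCS(=O)(=O)Nc1ccc(NC(=O)c2ccc(C#N)cc2)cc1F` has not yet been measured. It differs from compound 2 in one place: methyl in place of hydrogen on a saturated chain carbon bound to a sulfonyl sulfur. Compound 1, which also carries the ethylsulfonyl group, sits at the same limit.

Going by the values given here, no step between measured compounds is available to set a size for this change. Because compound 2 gives > 250000 nM in this assay, a step can only appear if compound 3 comes down into the measurable range, and that is not expected. The expected step that the limit leaves unreadable from compound 2 to compound 3 is none beyond the scatter. Compound 3 is estimated at 400000 nM, with a range from 150000 nM to 1500000 nM, most likely reported again as a limit.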

Compound 3, half-maximal inhibitory concentration: 26400 nM
For compound 3 the middle estimate is 15-fold (1.18 log units) above the measured one; measured number below the stated range.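

In this assay, going by these compounds alone, the change from methylsulfonyl to ethylsulfonyl on the fluoro-bearing compound gives the first step in this small set, an at least 9.4-fold lower number from compound 2 to compound 3 (0.97 log units; beyond the scatter), and here a lower number means a stronger effect on the cells. Exchanging methoxy for fluoro on the aromatic carbon, with the ethylsulfonyl group kept, gives an at least 9.4-fold lower number from compound 1 to compound 3 (0.97 log units; beyond the scatter), so this change at a different place in the molecule also matters. Neither the ethylsulfonyl group nor the fluoro group is enough alone, since only compound 3, which carries both, has left the limit that holds the other two values: the limit of > 250000 nM in this assay, at which 2 of the 3 values shown sit.

On these data alone, the full size of both steps stays unknown, since each starts from a value that is a limit and not a number. Still open, as far as these compounds go, is whether a longer chain such as propyl on the sulfonyl sulfur would bring the number lower again, and whether a chloro group in place of the fluoro group would keep the number of compound 3 or return it to the limit.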